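This account rests on a few compounds, and the source may have more. Where it says the series, first, only, none or still open, it means among the compounds named here.

Three sulfonamides built on the same core have been measured. Compound 1 `O=S(=O)(NCCCCNCc1ccc(Br)cc1)c1cc(C(F)(F)F)cc(C(F)(F)F)c1` gives 2900 nM in a functional assay on ASPC1 cells (Homo sapiens) for inhibition, read by MTT assay, with a stated time of 72 h; a lower number here means a stronger inhibitor of growth, a higher number a weaker inhibitor of growth. Compound 2 `O=S(=O)(NCCCNCc1ccccc1)c1cc(C(F)(F)F)cc(C(F)(F)F)c1` gives 13000 nM in this assay, and compound 3 `O=S(=O)(NCCCNCc1ccc(-c2ccccc2)cc1)c1cc(C(F)(F)F)cc(C(F)(F)F)c1` gives 2500 nM in this assay. Compound 3 has the lowest of the three numbers; its gap to compound 1 lies within the scatter, while the step of a 5.2-fold lower number from compound 2 to compound 3 (0.72 log units; beyond the scatter) lies beyond it, as does the step of a 4.5-fold higher number from compound 1 to compound 2 (0.65 log units; beyond the scatter).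

Compound 4 `O=S(=O)(NCCCNCc1ccc(Cl)cc1)c1cc(C(F)(F)F)cc(C(F)(F)F)c1` differs from compound 3 in one place: chloro in place of phenyl on an aromatic carbon. Among the compounds with values here, two measured steps bear on this change. The gain on going from compound 2 to compound 3 came with a phenyl entering where hydrogen had been; the step from compound 1 to compound 2 shows that taking a halogen-bearing benzyl away, together with a change of chain length, costs activity of similar size. A chloro in place of the phenyl is therefore expected to give back part, not all, of what the phenyl added, so compound 4 is expected to show a modest rise a 1.4-fold higher number from compound 3 to compound 4 (0.15 log units; within the scatter) in this assay. The estimate for compound 4 in this assay is 3500 nM, within a range of 1500 nM to 8500 nM.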

Compound 4, concentration for 50% growth inhibition: 3000 nM
Beside the measured number, compound 4's estimate is 1.2-fold (0.07 log units) above it; the measured number falls inside the stated range.
By their numbers in this assay, from the lowest: compounds 3, 1 and 4 (each within the scatter of the next); then compound 2.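

In this assay, the phenyl is not required on this aromatic carbon, para to a large group: a 1.2-fold higher number from compound 3 to compound 4 (0.08 log units; within the scatter), so the much smaller chloro cannot be told apart from it. Both groups stand clear of hydrogen at this position, as shown by a 4.3-fold lower number from compound 2 to compound 4 (0.64 log units; beyond the scatter), so the benefit seen with compound 3 is not confined to an added aromatic ring. Compound 1 also cannot be separated from compound 4, as a 1.0-fold higher number from compound 1 to compound 4 (0.01 log units; within the scatter) shows, with ((4-bromobenzyl)amino)methyl replaced by (4-chlorobenzyl)amino.

No supporting data explain why these groups give such similar results. The compounds shown leave open whether a methoxy group, a nitrile or an amine on this carbon would match chloro and phenyl, and how the bromo and the longer chain of compound 1 each contribute on their own.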